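Ester side-chain variation on the shared core

This account rests on a few compounds, and the source may have more. Where it says the series, first, only, none or still open, it means among the compounds named here.

The shared core is that of compound 1 `CC(C)=CC[C@@H](OC(=O)CC(C)(O)c1ccccc1)C1=CC(=O)c2c(O)ccc(O)c2C1=O`, which carries an ester on the side chain. In a functional assay on DU-145 cells (Homo sapiens) for cytotoxicity, read by MTT assay (on this read-out higher numbers stand for weaker inhibition and lower numbers for stronger inhibition), compound 1 gives > 100000 nM, a limit of the assay rather than a number (the limit of > 100000 nM in this assay, at which 1 of the 3 values shown sits). Compound 2 `COCCO[C@H](CC=C(C)C)C1=CC(=O)c2c(O)ccc(O)c2C1=O` and compound 3 `CC(C)=CC[C@@H](OCCO)C1=CC(=O)c2c(O)ccc(O)c2C1=O` carry ethers on that same position; in this assay compound 2 gives 43200 nM and compound 3 gives 9900 nM, the step of a 4.4-fold lower number from compound 2 to compound 3 (0.64 log units; beyond the scatter) being hydrogen in place of methyl on an oxygen on a saturated carbon. Compound 4 `CC(C)=CC[C@@H](OC(=O)C1CCCOC1)C1=CC(=O)c2c(O)ccc(O)c2C1=O` keeps the ester and differs from compound 1 by oxan-3-yl in place of 2-hydroxy-2-phenylpropyl on a carbonyl carbon. For the measured compounds named here, no measured step alters the acyl part of an ester, so the ether step gives only loose guidance. A change of an at least 2.0-fold lower number from compound 1 to compound 4 (0.30 log units; that floor lies within the scatter) is expected, toward a measurable but weak value. For compound 4 an estimate of 50000 nM with a range from 15000 nM to 200000 nM is expected in this assay.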

Compound 4, half-maximal inhibitory concentration: 29700 nM
The estimate for compound 4 lay 1.7-fold (0.23 log units) above the measured number; the range from low to high includes it.
By their numbers in this assay, from the lowest: compound 3; then compounds 4 and 2 (each within the scatter of the next). At a limit, above all of these: compound 1.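

In this assay the acyl part of the ester can move the number, with an at least 3.3-fold lower number from compound 1 to compound 4 (0.52 log units; beyond the scatter) for oxan-3-yl in place of 2-hydroxy-2-phenylpropyl on a carbonyl carbon. Compound 1 stands at a limit, so this step is a bound only: the limit of > 100000 nM in this assay, at which 1 of the 4 values shown sits. Against the ethers, a 1.5-fold lower number from compound 2 to compound 4 (0.16 log units; within the scatter) leaves the ester level with the 2-methoxyethyl ether, while a 3.0-fold higher number from compound 3 to compound 4 (0.48 log units; beyond the scatter) keeps the 2-hydroxyethyl ether ahead.

Open, as far as these compounds go, is whether an amine or a carboxylic acid on the acyl part would shift the number. Also open, from the compounds shown here alone, is whether a longer chain carrying the hydroxyl would hold the ether's standing.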